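The source may hold more compounds than are shown below. What is called first, only, known or untested is meant among the compounds shown, and "the series" means these compounds.

Measured so far in a functional assay on HT-29 cells (Homo sapiens) for cytotoxicity, read by MTT assay, with a stated time of 72 h; on this read-out higher numbers stand for weaker inhibition and lower numbers for stronger inhibition:
compound 1 `COc1cc2c(Oc3ccc(NC(=O)c4nn(-c5ccc(F)cc5)c(=O)c5ccccc45)cc3F)ccnc2cc1OCCCN1CCN(C)CC1` gives 320 nM.
compound 2 `COc1cc2c(Oc3ccc(NC(=O)c4nn(-c5ccc(F)cc5)c(=O)c5ccccc45)cc3F)ccnc2cc1OCCCN1CCC(C)CC1` gives 330 nM.

Compound 2 and compound 1 stand together: the step of a 1.0-fold higher number from compound 1 to compound 2 (0.01 log units; within the scatter) lies within the scatter, so neither can be placed above the other, even though 4-methylpiperidin-1-yl replaced 4-methylpiperazin-1-yl on a saturated chain carbon, three bonds along the chain from an oxygen on an aromatic ring. Compound 3 `COc1cc2c(Oc3ccc(NC(=O)c4nn(-c5ccc([N+](=O)[O-])cc5)c(=O)c5ccccc45)cc3F)ccnc2cc1OCCCN1CCC(C)CC1` is the next compound. It differs from compound 2 in nitro in place of fluoro on an aromatic carbon: on an aromatic carbon of a six-membered aromatic ring of carbon only, para to a large group, so that 4-fluorophenyl becomes 4-nitrophenyl. Among the measured compounds shown here, no measured step touches this ring; the one known step, between compound 1 and compound 2, concerns a different part of the molecule and gives no guide to size or direction here. Compound 3 is therefore expected to show a step of a 1.1-fold higher number from compound 2 to compound 3 (0.03 log units; within the scatter) that stays within the scatter. The estimate for compound 3 is 350 nM, with a range from 120 nM to 1000 nM.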

Compound 3, half-maximal inhibitory concentration: 2450 nM
The estimate for compound 3 lay 7.0-fold (0.85 log units) below the measured number; measured number outside the range, above it.
By their numbers in this assay, from the lowest: compounds 1 and 2 (each within the scatter of the next); then compound 3.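

Replacing the fluoro of 4-fluorophenyl with nitro gives a 7.4-fold higher number from compound 2 to compound 3 (0.87 log units; beyond the scatter) in this assay and so shows that this position on the aromatic ring can change the result beyond the usual scatter, which the earlier swap of 4-methylpiperazin-1-yl for 4-methylpiperidin-1-yl did not do with its a 1.0-fold higher number from compound 1 to compound 2 (0.01 log units; within the scatter). The change runs toward weaker inhibition, so of the two groups tried here, fluoro goes with the stronger inhibition on this scaffold. No measurement shown here accounts for the loss of inhibition.

On these data alone, with only fluoro and nitro at this position, it remains open whether the loss is particular to nitro or would also appear with a hydrogen, chloro, methoxy or an amine there. As far as these compounds go, it is also open whether nitro would give a similar step alongside 4-methylpiperazin-1-yl.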